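Difluoroanilide variant of a thiophene carboxamide: cytotoxicity outlook

The source may report more compounds than this note shows. Statements on the series, on what has been measured and on what is new or still open speak of the compounds shown alone.

Compound 1 `CC(C)n1ncc2c(C(=O)Nc3ccc(F)cc3)cc(-c3cccs3)nc21`, compound 2 `CC(C)n1ncc2c(C(=O)Nc3ccccn3)cc(C3CC3)nc21` and compound 3 `CC(C)n1ncc2c(C(=O)Nc3ccccn3)cc(-c3ccccc3)nc21` share a core carboxamide and were tested in an ADME assay on LLC-MK2 cells (Macaca mulatta) for cytotoxicity, read by spectrophotometry and crystal violet staining, with a stated time of 4 days; on this read-out higher numbers stand for lower toxicity in this test and lower numbers for higher toxicity in this test. In this assay, going by the values given here, compound 2 gives 25000 nM and compound 3 gives 12500 nM; the only single-point step measured, a 2.0-fold lower number from compound 2 to compound 3 (0.30 log units; within the scatter), concerns the substituent on an aromatic carbon. For compound 1 this assay reports only a limit, > 200000 nM, so compound 1 stands at the limit of > 200000 nM in this assay, at which 1 of the 3 values shown sits. Compound 4 `CC(C)n1ncc2c(C(=O)Nc3cc(F)ccc3F)cc(-c3cccs3)nc21` differs from compound 1 by 2,5-difluorophenyl in place of 4-fluorophenyl on an amide-type nitrogen. The measured step lies elsewhere and is within the scatter, so no step beyond the scatter is expected here; the expected step is a number no higher from compound 1 to compound 4 (the limit leaves the size open). Compound 4 is therefore expected to give about 200000 nM, estimated between 50000 nM and 400000 nM.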

Compound 4, half-maximal cytotoxic concentration: 100000 nM
For compound 4 the middle estimate is 2.0-fold (0.30 log units) above the measured one; low and high end bracket the measured number.
By their numbers in this assay, from the lowest: compounds 3 and 2 (each within the scatter of the next); then compound 4. At a limit, above all of these: compound 1.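

In this assay the first step read at the amide-type nitrogen is an at least 2.0-fold lower number from compound 1 to compound 4 (0.30 log units; that floor lies within the scatter). Compound 4 gives this position a true number, and it shows that the swap to 2,5-difluorophenyl can be followed in this test only from one side. Compound 1 holds a limit, so the real size of the step stays unread: the limit of > 200000 nM in this assay, at which 1 of the 4 values shown sits.

The compounds shown leave open how an amine or a carboxylic acid on this anilide phenyl would read in this assay. They also leave open whether 2,5-difluorophenyl would read alike with cyclopropyl on the aromatic carbon.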